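Replacing a Methoxy Group on a Shared Aromatic Ring

The compounds below may be only part of what the source reports. "The series", "measured", "known", "first", "only" and "open" are said of these compounds alone.

Compound 3 `CCOC(=O)c1cccc(-c2ccc(OC)cc2)c1` belongs to a small set of three compounds that was examined in an assay on COS-7 cells for inhibition of patatin-like phospholipase domain-containing protein 2 (Mus musculus), tested at 200 uM; on this read-out higher numbers stand for more inhibition at the one concentration tested (going by the name of the read-out) and lower numbers for less inhibition. In this assay compound 3 gives 77%. Alongside it stand compound 1 `CCOC(=O)c1ccnc(-c2ccc(OCC)cc2)c1`, which in this assay gives 87%, and compound 2 `CCOC(=O)c1cncc(-c2ccc(OCC)cc2)c1`, which gives 70%. Compound 3 sits between the other two, and both of its gaps lie within the usual scatter of repeated measurements, so the three numbers cannot be told apart with confidence. Compound 4 `CCOC(=O)c1cccc(-c2ccc(C(C)N(C)C)cc2)c1` has not yet been measured. It differs from compound 3 by 1-(dimethylamino)ethyl in place of methoxy on an aromatic carbon, the group sitting on an aromatic carbon of a six-membered aromatic ring of carbon only, para to a large group. For the measured compounds named here, no pair of measured compounds shows this change, so no measured step guides the expectation; the three numbers show only that this set gives substantial inhibition at the tested concentration. The step of a number 7 percentage points lower from compound 3 to compound 4 (within the scatter) is therefore expected to be small, if anything downward, and not beyond the scatter. Compound 4 is accordingly estimated at 70%, with a range from 40% to 90%.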

Compound 4, a percentage reported as inhibition, at one concentration (the size of the read-out at that concentration, not a potency): 50%
For compound 4 the middle estimate is 20 percentage points above the measured one, and the stated range covers the measured number.
By their numbers in this assay, from the lowest: compound 4; then compounds 2, 3 and 1 (each within the scatter of the next, the first and the last beyond it).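

In this assay, 1-(dimethylamino)ethyl in place of methoxy gives a number 27 percentage points lower from compound 3 to compound 4 (beyond the scatter), the first step measured at this position, on an aromatic carbon para to a large group. It shows that the read-out responds to the group at this place, yet the change does not abolish inhibition, since compound 4 still gives 50%. Nothing measured here accounts for the size of this step.

The compounds shown do not separate the contribution of the amine nitrogen from that of the carbon chain, which a plain ethyl group or a dimethylamino group at the same place could address. Going by these compounds, it also remains open whether a carboxylic acid would be accepted here, and whether the same replacement would give a comparable step on the core of compound 1.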